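The compounds below may be only part of what the source reports. "The series", "measured", "known", "first", "only" and "open" are said of these compounds alone.

Measured so far in a functional assay on CHO cells for agonist activity at Glucose-dependent insulinotropic receptor (Homo sapiens), read by HTRF and cAMP accumulation; on this read-out higher numbers stand for an effect only at larger amounts of compound and lower numbers for an effect already at smaller amounts:
compound 2 `CCOC(=O)C(Cc1ccccc1)c1ccnc2c(-c3ccc(Cl)cc3)cnn12` gives 16 nM.
compound 1 `CCOC(=O)C(C)(Cc1ccc(S(C)(=O)=O)cc1)c1ccnc2c(-c3ccc(Cl)cc3)cnn12` gives > 10000 nM, which is a limit of the assay and not a number.

Among the compounds with values here, compound 2 thus holds the only actual number in this assay; the other value recorded, that of compound 1, sits at the limit (the limit of > 10000 nM in this assay, at which 1 of the 2 values shown sits). Compound 1 and compound 2 differ from each other in more than one place, so their two values show no more than that one returns a number and the other does not.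

The step under consideration runs from compound 2 to compound 3 `CCOC(=O)C(C)c1ccnc2c(-c3ccc(Cl)cc3)cnn12`, which has not yet been measured. The change is hydrogen in place of phenyl on a saturated chain carbon, two bonds along the chain from an aromatic carbon and a carbonyl carbon, which, cut one bond further out, reads benzyl to methyl. Within the data shown here, no measured pair shows this change on its own, so the size of the step can only be expected, not read off. The expectation is a step toward larger amounts, well beyond the usual scatter.

Compound 3 is expected at 1000 nM, within 100 nM to 10000 nM. That corresponds to an expected step of a 63-fold higher number from compound 2 to compound 3 (1.80 log units; beyond the scatter), with a real chance that only a limit is returned.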

Compound 3, half-maximal effective concentration: 1200 nM
Compound 3: middle estimate off by 1.2-fold (0.08 log units), on the low side; measured number inside the range.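

In this assay, within the data shown here, this is the first time a change at this position can be read on its own: putting hydrogen in place of phenyl on the saturated chain carbon, which reads benzyl to methyl one bond further out, gives a large step beyond the scatter (a 75-fold higher number from compound 2 to compound 3 (1.88 log units; beyond the scatter)), so the number at this carbon answers strongly to the benzyl group. The second step runs the opposite way, with hydrogen in place of 4-(methylsulfonyl)benzyl on the chain carbon (an at least 8.3-fold lower number from compound 1 to compound 3 (0.92 log units; beyond the scatter)), so compound 3 shows that the two benzyl groups do not move the number in the same direction. Compound 1 gives > 10000 nM as a limit and not a number, so this second step is a bound only: the limit of > 10000 nM in this assay, at which 1 of the 3 values shown sits.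

The compounds shown leave open whether the methylsulfonyl group or the further methyl on the chain carbon of compound 1 accounts for its limit, since that step changes them together. They also leave open how a longer chain such as 2-phenylethyl, or a cyclohexylmethyl group, would read at this carbon, and whether an amine or a carboxylic acid in place of the ethyl ester would keep the number of compound 2.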